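The source may report more compounds than this note shows. Statements on the series, on what has been measured and on what is new or still open speak of the compounds shown alone.

Measured in an ADME assay on Vero cells (Chlorocebus sabaeus) for cytotoxicity; a higher number here means that more compound is tolerated, a lower number that less compound is tolerated:
- compound 1 `CCCCCC(=O)Nc1nc(N)nc2c1ncn2[C@H]1CO[C@@H](CO)O1`: > 100000 nM
- compound 2 `CCCCCCCC(=O)Nc1nc(N)nc2c1ncn2[C@H]1CO[C@@H](CO)O1`: > 100000 nM
- compound 3 `CCCCCCCCCC(=O)Nc1nc(N)nc2c1ncn2[C@H]1CO[C@@H](CO)O1`: > 100000 nM

Compound 3 stands at > 100000 nM, which is a limit of the assay and not a number. Among the compounds with values here, the series so far shows (the limit of > 100000 nM in this assay, at which 3 of the 3 values shown sit).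

Compound 4 `CCCCCCCCCCCC(=O)Nc1nc(N)nc2c1ncn2[C@H]1CO[C@@H](CO)O1` differs from compound 3 by ethyl in place of hydrogen on a saturated chain carbon, nine bonds along the chain from a carbonyl carbon. The same kind of chain extension appears in a step that the two limits leave unreadable from compound 1 to compound 2, in a step that the two limits leave unreadable from compound 2 to compound 3 and in a step that the two limits leave unreadable from compound 1 to compound 3. None of these gives a size to carry forward.

Resting on a step that the two limits leave unreadable from compound 2 to compound 3, no step beyond the usual scatter is expected in this assay. The estimated step is a number no higher from compound 3 to compound 4 (the limit leaves the size open). Compound 4 is expected at 100000 nM, with an estimated range of 50000 nM to 200000 nM.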

Compound 4, half-maximal cytotoxic concentration: 53000 nM
The estimate for compound 4 lay 1.9-fold (0.28 log units) above the measured number, within the range that was stated.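

In this assay, compound 4 alone gives a measured number at this position, while the shorter chains all sit at a limit of the assay: the limit of > 100000 nM in this assay, at which 3 of the 4 values shown sit.

Ethyl in place of hydrogen, nine bonds along the chain from a carbonyl carbon, gives an at least 1.8-fold lower number from compound 3 to compound 4 (0.27 log units; that floor lies within the scatter), and the wider chain differences give an at least 1.8-fold lower number from compound 2 to compound 4 (0.27 log units; that floor lies within the scatter) and an at least 1.8-fold lower number from compound 1 to compound 4 (0.27 log units; that floor lies within the scatter). On these data alone, these are floors whose full size stays open, and the steps among compound 1, compound 2 and compound 3 cannot be read.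

Open, as far as these compounds go, is whether a longer chain carries the number further down. Also open, from the compounds shown here alone, is how an amine or a carboxylic acid at the chain end would read.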